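Sulfonamide heteroaryl swap on a diterpenoid lactone, untested cells

This account rests on a few compounds, and the source may have more. Where it says the series, first, only, none or still open, it means among the compounds named here.

Measured compounds:
Compound 1, `C=C1CC[C@@H]2[C@](C)(COC(C)=O)[C@H](OC(C)=O)CC[C@@]2(C)[C@H]1CC(Nc1ccc(S(=O)(=O)Nc2ccc(Cl)nn2)cc1)C1=CCOC1=O`: in a functional assay on CCRF-CEM cells (Homo sapiens) for inhibition, read by sulforhodamine B assay, with a stated time of 48 h (a lower number here means that less compound is tolerated, a higher number that more compound is tolerated), compound 1 reaches only the limit > 100000 nM.
Compound 2, `C=C1CC[C@@H]2[C@](C)(COC(C)=O)[C@H](OC(C)=O)CC[C@@]2(C)[C@H]1CC(Nc1ccc(S(=O)(=O)Nc2cc(C)on2)cc1)C1=CCOC1=O`: in this assay compound 2 likewise gives only the limit > 100000 nM.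

Compound 2 therefore stands at the limit, as does compound 1; the step that the two limits leave unreadable from compound 1 to compound 2 cannot be read, since both ends are limits (the limit of > 100000 nM in this assay, at which 2 of the 2 values shown sit). For the measured compounds named here, compound 3, `C=C1CC[C@@H]2[C@](C)(COC(C)=O)[C@H](OC(C)=O)CC[C@@]2(C)[C@H]1CC(Nc1ccc(S(=O)(=O)Nc2nccc(C)n2)cc1)C1=CCOC1=O`, differs from compound 2 by the change (4-methylpyrimidin-2-yl in place of 5-methyl-1,2-oxazol-3-yl on a sulfonamide nitrogen), a heteroaryl exchange of the same kind as the one between compound 1 and compound 2. Going by the values given here, only that unreadable step bears on it, so no direction can be drawn from it. Since both measured compounds sit at the limit, compound 3 is expected to sit there too, with a step of a number no higher from compound 2 to compound 3 (the limit leaves the size open) that is expected to be nil. Compound 3 is estimated at 100000 nM, within 30000 nM to 300000 nM.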

Compound 3, concentration lethal to 50% of the cells: > 100000 nM
Compound 3: a limit, no number; the forecaster's own chance of this, stated with the estimate: 85%; the middle value lies on the limit itself.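

Compound 3 gives > 100000 nM in this assay and this is a limit. For the compounds shown here, no step among compound 1, compound 2 and compound 3 can be read: the limit of > 100000 nM in this assay, at which 3 of the 3 values shown sit.

The compounds shown leave open how these three sulfonamide heteroaryl groups would rank if their values could be read as numbers.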